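From Methoxy to Bromo: An Expected Gain in Potency

The compounds below may be only part of what the source reports. "The series", "measured", "known", "first", "only" and "open" are said of these compounds alone.

Measured so far:
compound 1 `O=C(Nc1cc(C(F)(F)F)cc(C(F)(F)F)c1)c1cc(Br)c(-c2ccccc2)cc1O` gives 430 nM in a functional assay on HL-60 cells (Homo sapiens) for cytotoxicity, read by luminescence and CellTiter-Glo, with a stated time of 3 days; a higher number here means a weaker inhibitor, a lower number a stronger inhibitor
compound 3 `O=C(Nc1ccc(Cl)c(Cl)c1)c1cc(F)ccc1O` gives 660 nM in this assay
compound 2 `COc1cccc(C(=O)Nc2ccc(C#N)cc2)c1O` gives only a limit of the assay, > 10000 nM, in this assay

The three measured compounds share an amide that links two aromatic rings, with a hydroxy group on the ring that bears the carbonyl. Compound 1 and compound 3 each carry a halogen and give numbers inside the measurable range. Compound 2 stands apart: its result is a limit rather than a number, and it sits at the limit of > 10000 nM in this assay, at which 1 of the 3 values shown sits. Going by the values given here, no two measured compounds differ in a single place, so no step between them can be read off directly.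

Compound 4 `N#Cc1ccc(NC(=O)c2cccc(Br)c2O)cc1` differs from compound 2 in one place: bromo in place of methoxy on an aromatic carbon. With bromo in place of methoxy, compound 4 comes to resemble compound 1 and compound 3, which also carry a halogen, while it keeps the nitrile-bearing ring of compound 2. A step toward stronger inhibition in this assay, beyond the usual scatter, is therefore expected, though its size is uncertain, and compound 4 is estimated at 3000 nM, within 500 nM to 20000 nM. The expected step is an at least 3.3-fold lower number from compound 2 to compound 4 (0.52 log units; beyond the scatter), with a real chance that compound 4 again returns only a limit.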

Compound 4, half-maximal inhibitory concentration: 2910 nM
Beside the measured number, compound 4's estimate is 1.0-fold (0.01 log units) above it; the range from low to high includes it.
By their numbers in this assay, from the lowest: compounds 1 and 3 (each within the scatter of the next); then compound 4. At a limit, above all of these: compound 2.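

Going by these compounds alone, replacing methoxy with bromo on this aromatic carbon, ortho to a hydroxy group, gives an at least 3.4-fold lower number from compound 2 to compound 4 (0.53 log units; beyond the scatter), the first step in one place that can be read in this assay. Compound 4 gives 2910 nM, so a compound that keeps the nitrile-bearing ring of compound 2 can give a number inside the measurable range when bromo holds this position. The step can only be read as a minimum, and its full size remains unknown because the result for compound 2 is a limit and not a number: the limit of > 10000 nM in this assay, at which 1 of the 4 values shown sits.

The compounds shown leave open whether the gain depends on bromo itself or on the loss of methoxy, a question that plain hydrogen, chloro or an amine at this position could help to separate. They also leave open whether the same replacement would give a similar step on a compound with a different group in place of the nitrile-bearing ring, such as the dichlorophenyl ring of compound 3.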